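The source may hold more compounds than are shown below. What is called first, only, known or untested is meant among the compounds shown, and "the series" means these compounds.

In a functional assay on SK-MEL-28 cells (Homo sapiens) for inhibition, read by colorimetric assay and MTT assay, with a stated time of 72 h (on this read-out lower numbers stand for stronger inhibition and higher numbers for weaker inhibition), compound 1 `Cn1c2cnc1OCCCCCCCCOc1cc(F)ccc1-2` gives 58000 nM, compound 2 `C=CCCCCOc1cc2ccccc2cc1-c1cnc(OCCC=C)n1C` gives 25000 nM, and compound 3 `C=CCCCCOc1ccccc1-c1cnc(OCCCC=C)n1C` gives 19000 nM. Compound 3 and compound 2 lie within the scatter of each other, while compound 1 has a higher number than compound 3, beyond the scatter. Compound 4 `C=CCCCCOc1ccccc1-c1cnc(S(=O)(=O)c2ccccc2)n1C` has phenylsulfonyl in place of (pent-4-en-1-yl)oxy on an aromatic carbon, between two ring nitrogen atoms: phenylsulfonyl in place of (pent-4-en-1-yl)oxy on an aromatic carbon. Among the compounds with values here, no measured pair shows this change, so the expectation in this assay is tentative, with no step beyond the scatter foreseen. The estimated step is a 1.3-fold lower number from compound 3 to compound 4 (0.10 log units; within the scatter). Compound 4 is expected at 15000 nM, with an estimated range of 5000 nM to 50000 nM.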

Compound 4, half-maximal inhibitory concentration: 38000 nM
Compound 4: middle estimate off by 2.5-fold (0.40 log units), on the low side, and the stated range covers the measured number.
By their numbers in this assay, from the lowest: compounds 3, 2, 4 and 1 (each within the scatter of the next, the first and the last beyond it).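

In this assay, placing phenylsulfonyl in place of (pent-4-en-1-yl)oxy on this aromatic carbon, between two ring nitrogen atoms, gives a 2.0-fold higher number from compound 3 to compound 4 (0.30 log units; within the scatter). This carbon therefore carries either the open chain with its double bond or a group with a six-membered aromatic ring, with no step beyond the scatter between them. Nothing at hand gives a reason for this result. As far as these compounds go, whether an amine or a carboxylic acid on this carbon would move the number beyond the scatter remains open. So does the effect of a longer chain there.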